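A few compounds are considered here, and "the series" means these few. Any claim that something is new, unique, unknown or untested is made for them only; others in the source may bear on it.

Of the compounds shown here, three have been measured so far in an assay on HL-60 cells for inhibition of cytochrome P450 26A1 (Homo sapiens), read by HPLC, using microsomes and NADPH, with a stated time of 30 min; on this read-out higher numbers stand for weaker inhibition and lower numbers for stronger inhibition. Compound 1 `CCOC(=O)C(Cn1ccnc1)NC(=O)c1ccc(-c2ccccc2)cc1` gives 650 nM in this assay, and compound 2 `CC(C)OC(=O)C(Cn1ccnc1)NC(=O)c1ccc(-c2ccccc2)cc1` gives 540 nM. The change between them, (methyl in place of hydrogen on a saturated chain carbon bound to an oxygen next to a carbonyl group and a saturated chain carbon), produced a 1.2-fold lower number from compound 1 to compound 2 (0.08 log units; within the scatter). Compound 3 `COC(=O)C(Cn1ccnc1)NC(=O)c1nc2ccccc2s1` carries a different core; how its core differs from that of compound 1 is not broken down here. In this assay compound 3 gives 410 nM, a number that sits within the scatter of those for compound 1 and compound 2. Compound 4 `CCOC(=O)C(Cn1ccnc1)NC(=O)c1nc2ccccc2s1` has not yet been measured. It differs from compound 3 by methyl in place of hydrogen on a saturated chain carbon bound to an oxygen next to a carbonyl group. This is the same kind of change as that between compound 1 and compound 2, but not the same: in compound 3 the carbon that receives the methyl is bound to an oxygen next to a carbonyl group, while in compound 1 it is bound to an oxygen next to a carbonyl group and a saturated chain carbon. Resting on the small size of a 1.2-fold lower number from compound 1 to compound 2 (0.08 log units; within the scatter), a similarly small step is expected, a 1.2-fold lower number from compound 3 to compound 4 (0.07 log units; within the scatter). Compound 4 is therefore estimated at 350 nM, with a likely range from 180 nM to 700 nM.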

Compound 4, half-maximal inhibitory concentration: 740 nM
Compound 4: the middle estimate sits 2.1-fold (0.33 log units) below what was measured; the whole stated range lies below it.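

In this assay, the methyl added on a saturated chain carbon bound to an oxygen next to a carbonyl group, here turning methoxycarbonyl into ethoxycarbonyl, gives a 1.8-fold higher number from compound 3 to compound 4 (0.26 log units; within the scatter), and set beside the earlier step on the other core it shows no difference that can be told from scatter: the same change on two cores in this assay, a 1.2-fold lower number (0.08 log units; within the scatter) from compound 1 to compound 2 and a 1.8-fold higher number (0.26 log units; within the scatter) from compound 3 to compound 4, 2.2-fold (0.34 log units) apart, within the scatter of two such steps

So the two cores give no sign that this change behaves differently from one to the other, and neither step on its own shows that the added methyl does anything to the number. It does not show that the change carries over reliably, since two small steps on two cores can neither confirm nor exclude a modest dependence on the core.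

The compounds shown hold only small esters on these two cores. As far as these compounds go, whether a longer chain in place of the ethyl of ethoxycarbonyl, or a carboxylic acid in place of the whole ester, would move the number beyond the scatter on either core remains open.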